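Amide substituent on the shared core: trifluoromethyl to chloropyrimidinyl

The source may report more compounds than this note shows. Statements on the series, on what has been measured and on what is new or still open speak of the compounds shown alone.

Measured compounds: compound 1, `Cc1nc(S(C)(=O)=O)ccc1Oc1ncnc(OC2CCN(C(=O)SC3CC3)CC2)c1F`, in a functional assay on isolated protein for inhibition of Glucose-dependent insulinotropic receptor (Rattus norvegicus), read by HTRF and cAMP accumulation (a higher number here means that more compound is needed for the effect, a lower number that less compound is needed), gives 126 nM; compound 2, `Cc1nc(S(C)(=O)=O)ccc1Oc1ncnc(OC2CCN(C(=O)C(F)(F)F)CC2)c1F`, in this assay gives 880 nM.

Compound 2 stands highest of the two numbers measured, and its nearest neighbour is compound 1, separated by the step of a 7.0-fold higher number from compound 1 to compound 2 (0.84 log units; beyond the scatter). Compound 3, `Cc1nc(S(C)(=O)=O)ccc1Oc1ncnc(OC2CCN(C(=O)c3ncc(Cl)cn3)CC2)c1F`, is not yet measured; relative to compound 2 it carries 5-chloropyrimidin-2-yl in place of trifluoromethyl on a carbonyl carbon. Among the measured compounds shown here, the only measured step at this carbonyl carbon is a 7.0-fold higher number from compound 1 to compound 2 (0.84 log units; beyond the scatter), which shows that exchanging the group here moves the number well beyond the scatter. A reversal of that direction is expected, estimated as a 5.9-fold lower number from compound 2 to compound 3 (0.77 log units; beyond the scatter). Compound 3 is expected to give 150 nM, within 40 nM to 600 nM.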

Compound 3, half-maximal effective concentration: 30.9 nM
Compound 3: middle estimate off by 4.9-fold (0.69 log units), on the high side; measured number outside the range, below it.
By their numbers in this assay, from the lowest: compound 3; then compound 1; then compound 2.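

On this carbonyl carbon, the exchange of trifluoromethyl for 5-chloropyrimidin-2-yl gives the largest change so far in this assay (a 28-fold lower number from compound 2 to compound 3 (1.45 log units; beyond the scatter)), showing that a six-membered aromatic ring is accepted here. The same ring also improves on the cyclopropylthio group (a 4.1-fold lower number from compound 1 to compound 3 (0.61 log units; beyond the scatter)), so the position has more room for gain than the first pair suggested. Nothing measured here accounts for either step.

On these data alone, it remains open whether the chlorine, the ring nitrogens or the ring itself carries the gain. Unsubstituted pyrimidin-2-yl, phenyl or 5-methoxypyrimidin-2-yl on this carbonyl carbon would separate these.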